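Cyano to 2-Chloroethenyl: Expected Cytotoxicity of Compound 3

A few compounds are considered here, and "the series" means these few. Any claim that something is new, unique, unknown or untested is made for them only; others in the source may bear on it.

Two compounds were measured in an ADME assay on L1210/0 cells (Mus musculus) for cytotoxicity, with a stated time of 48 h; on this read-out lower numbers stand for stronger inhibition and higher numbers for weaker inhibition. Compound 1 `OC[C@H]1C[C@@H](Cn2cnc3c(-c4ccccc4)ncnc32)c2ccccc21` gives 28100 nM. Compound 2 `N#Cc1cn([C@H]2C[C@H](O)[C@@H](CO)O2)c(=O)[nH]c1=O` yields only a limit of the assay, > 200000 nM. It thus sits at the limit of > 200000 nM in this assay, at which 1 of the 2 values shown sits. Compound 3 `O=c1[nH]c(=O)n([C@H]2C[C@H](O)[C@@H](CO)O2)cc1/C=C/Cl` carries 2-chloroethenyl in place of cyano on an aromatic carbon. Among the compounds with values here, no measured pair shows how this change moves the read-out in this assay, so a shift beyond the usual scatter in either direction remains open, with weak activity the more likely outcome. Compound 3 is expected near 150000 nM, within 30000 nM to 400000 nM. That estimate corresponds to an expected step of an at least 1.3-fold lower number from compound 2 to compound 3 (0.12 log units; that floor lies within the scatter).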

Compound 3, half-maximal inhibitory concentration: > 200000 nM
Compound 3 gave a limit, no number; the forecaster's own chance of this, stated with the estimate: 55%; middle value at least 1.3-fold (0.12 log units) from the limit.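

In this assay compound 3 gives > 200000 nM, a limit and not a number. Within the data shown here, compound 2 also gave a limit, so no step between compound 2 and compound 3 can be read. From the compounds shown here alone, whether 2-chloroethenyl in place of cyano moves the read-out at all stays open.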